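This account rests on a few compounds, and the source may have more. Where it says the series, first, only, none or still open, it means among the compounds named here.

Compound 1 `CCOC(=O)C1=C(C)NC(C)=C(C(=O)OCC)C1c1csc(-c2ccc(Cl)cc2)n1`, compound 2 `CCOC(=O)C1=C(C)NC(C)=C(C(=O)OC(C)(C)C)C1c1csc(-c2ccc(Cl)cc2)n1` and compound 3 `CCOC(=O)C1=C(C)NC(C)=C(C(=O)OCc2ccccc2)C1c1csc(-c2ccc(Cl)cc2)n1` have been measured in an assay on isolated protein for antagonist activity at Voltage-dependent L-type calcium channel subunit alpha-1C (Cavia porcellus), with a stated time of 15 min; a lower number here means a stronger inhibitor, a higher number a weaker inhibitor. Compound 1 gives 3650 nM. Compound 2 gives 91000 nM. Compound 3 gives 3290 nM.

Compound 3 has the lowest of the three numbers. Its nearest neighbour is compound 1, with a 1.1-fold lower number from compound 1 to compound 3 (0.05 log units; within the scatter), so these two cannot be told apart. Its furthest is compound 2, with a 28-fold lower number from compound 2 to compound 3 (1.44 log units; beyond the scatter).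

Compound 4 `CCOC(=O)C1=C(C)NC(C)=C(C(=O)OC(C)c2ccccc2)C1c1csc(-c2ccc(Cl)cc2)n1` differs from compound 3 by methyl in place of hydrogen on a saturated chain carbon bound to an aromatic carbon and an oxygen next to a carbonyl group. The step that bears on this change is a 25-fold higher number from compound 1 to compound 2 (1.40 log units; beyond the scatter), where carbon was likewise added at the saturated chain carbon bound to the oxygen next to the carbonyl group; there the entering group was tert-butyl, a larger addition than the single methyl entering here. The step of a 1.1-fold lower number from compound 1 to compound 3 (0.05 log units; within the scatter) shows that the benzyl ester itself sits at the level of the ethyl ester. A move in the same direction as compound 2, but smaller, is therefore expected. For compound 4 the expected step is a 2.1-fold higher number from compound 3 to compound 4 (0.33 log units; beyond the scatter), which gives an estimate of 7000 nM, with a range from 2500 nM to 25000 nM.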

Compound 4, half-maximal inhibitory concentration: 13800 nM
Compound 4: middle estimate off by 2.0-fold (0.29 log units), on the low side, within the range that was stated.
By their numbers in this assay, from the lowest: compounds 3 and 1 (each within the scatter of the next); then compound 4; then compound 2.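

A single methyl on this saturated chain carbon is enough to shift the number in this assay, with a 4.2-fold higher number from compound 3 to compound 4 (0.62 log units; beyond the scatter), so the level shared by the ethyl and benzyl esters does not survive this addition. The 1-phenylethyl ester still keeps much of what the tert-butyl ester loses, with a 6.6-fold lower number from compound 2 to compound 4 (0.82 log units; beyond the scatter), which places a single added carbon well short of the full tert-butyl penalty among the compounds shown. Phenyl is also not neutral when it replaces hydrogen on a saturated chain carbon bound to an oxygen next to a carbonyl group and a saturated chain carbon, with a 3.8-fold higher number from compound 1 to compound 4 (0.58 log units; beyond the scatter), unlike the phenyl of compound 3.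

Nothing available explains these steps. On these data alone, it remains open how a longer chain, such as propyl, in place of the added methyl would read, and how the other ester, an ethyl ester in all four compounds, would respond to the same change.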